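The compounds below may be only part of what the source reports. "The series", "measured", "known", "first", "only" and "open" are said of these compounds alone.

Of the compounds shown here, three have been tested so far in a functional assay on DU-145 cells (Homo sapiens) for cytotoxicity, read by trypan blue exclusion, with a stated time of 96 h; on this read-out lower numbers stand for stronger inhibition and higher numbers for weaker inhibition. Compound 1 `COc1ccc(CS(=O)(=O)/C=C/c2c(OC)cccc2OC)c([N+](=O)[O-])c1` gives 50000 nM. Compound 3 `COc1cc(OC)c(/C=C/S(=O)(=O)Cc2ccc(OC)cc2[N+](=O)[O-])c(OC)c1` gives 20000 nM. Compound 2 `COc1ccc(OC)c(/C=C/S(=O)(=O)Cc2ccc(OC)c(N)c2)c1` gives 750 nM, the lowest number of the three. How the core of compound 2 differs from the core of compound 1 is not broken down here. Compound 4 `COc1ccc(CS(=O)(=O)/C=C/c2cc(OC)c(OC)cc2OC)cc1N` is not yet measured.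

The change from compound 1 to compound 3 is methoxy in place of hydrogen on an aromatic carbon, and it made the step of a 2.5-fold lower number from compound 1 to compound 3 (0.40 log units; beyond the scatter). The change leading to compound 4 is methoxy in place of hydrogen on an aromatic carbon, the same kind of change, though here the entering methoxy sits ortho to a methoxy group and meta to a methoxy group rather than meta to two methoxy groups. A similar modest step is expected, a 1.9-fold lower number from compound 2 to compound 4 (0.27 log units; within the scatter), because the earlier step was a 2.5-fold lower number from compound 1 to compound 3 (0.40 log units; beyond the scatter). For compound 4 the expected value is 400 nM, with a likely range from 150 nM to 1500 nM.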

Compound 4, half-maximal inhibitory concentration: 250 nM
Beside the measured number, compound 4's estimate is 1.6-fold (0.20 log units) above it; low and high end bracket the measured number.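

In this assay, methoxy in place of hydrogen on an aromatic carbon gave a 3.0-fold lower number from compound 2 to compound 4 (0.48 log units; beyond the scatter), and the same change now reads much the same on two different cores: the same change on two cores in this assay, a 2.5-fold lower number (0.40 log units; beyond the scatter) from compound 1 to compound 3 and a 3.0-fold lower number (0.48 log units; beyond the scatter) from compound 2 to compound 4, 1.2-fold (0.08 log units) apart, within the scatter of two such steps. In this small set, then, the change carried over from one core to the other, with a modest step each time. Among these compounds, two pairs are still only two examples, the entering methoxy does not sit in the same place on both cores, and these numbers do not show why the values fall or whether the step would hold on every core.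

The compounds shown leave open whether another group in that place, such as an ethoxy group, a hydroxyl group or a fluorine atom, would give a similar step.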